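Amide aryl swap in a cytotoxicity series: compound 2 to 3

A few compounds are considered here, and "the series" means these few. Any claim that something is new, unique, unknown or untested is made for them only; others in the source may bear on it.

Compound 1 `COc1cc2nc(SCC(=O)Nc3cccc(Cl)c3)nc(Nc3c(Cl)cc(/C=C/C#N)cc3Cl)c2cc1OC` and compound 2 `COc1cc2nc([S+]([O-])CC(=O)Nc3ccccc3F)nc(Nc3c(Cl)cc(/C=C/C#N)cc3Cl)c2cc1OC` share one core and differ at the amide and at the sulfur. In an ADME assay on MT4 cells (Homo sapiens) for cytotoxicity, read by MTT assay, with a stated time of 5 days (on this read-out higher numbers stand for lower toxicity in this test and lower numbers for higher toxicity in this test), compound 1 gives only a limit, > 208000 nM. In this assay compound 2 likewise gives only a limit, > 208000 nM. Compound 2 thus stands at the limit, where both values shown sit (the limit of > 208000 nM in this assay, at which 2 of the 2 values shown sit). Compound 3 `COc1cc2nc([S+]([O-])CC(=O)Nc3ccc(C)cc3)nc(Nc3c(Cl)cc(/C=C/C#N)cc3Cl)c2cc1OC` carries 4-methylphenyl in place of 2-fluorophenyl on an amide-type nitrogen. Going by the values given here, no measured step between compounds is available. The step of a number no higher from compound 2 to compound 3 (the limit leaves the size open) is expected to be none beyond the scatter. Compound 3 is expected to give 208000 nM, within 100000 nM to 400000 nM, most likely reported again only as a limit.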

Compound 3, half-maximal cytotoxic concentration: 32200 nM
The estimate for compound 3 lay 6.5-fold (0.81 log units) above the measured number; measured number below the stated range.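

In this assay, the aryl group on the amide-type nitrogen proves able to shift the read-out: 4-methylphenyl in place of 2-fluorophenyl gives an at least 6.4-fold lower number from compound 2 to compound 3 (0.81 log units; beyond the scatter). Going by these compounds, this swap therefore moves the series towards higher toxicity in this test, although the size of the step remains open. Compound 3 alone gives a number rather than a limit, and the other two stay at the limit: the limit of > 208000 nM in this assay, at which 2 of the 3 values shown sit.

The compounds shown do not separate the gain of the methyl from the loss of the fluorine. On these data alone, how an unsubstituted phenyl or a 4-methoxyphenyl on the same nitrogen would read also remains open.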